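This account rests on a few compounds, and the source may have more. Where it says the series, first, only, none or still open, it means among the compounds named here.

Working notes on the series. In a functional assay on MCF7 cells (Homo sapiens) for cytotoxicity, read by MTT assay, with a stated time of 48 h (on this read-out higher numbers stand for weaker inhibition of growth and lower numbers for stronger inhibition of growth), compound 1 (`CC(C)c1nc2cc(Cl)c(Cl)cc2[nH]1`) gives 57000 nM and compound 2 (`Clc1cc2nc(-c3ccccc3Cl)[nH]c2cc1Cl`) gives 22000 nM as the lower of the two numbers, a gap beyond the scatter. Compound 3 (`Fc1ccccc1-c1nc2cc(Cl)c(Cl)cc2[nH]1`) differs from compound 2 by fluoro in place of chloro on an aromatic carbon in one place: fluoro in place of chloro on an aromatic carbon, ortho to a large group. Among the compounds with values here, no measured pair shows this exchange, so only a slight drift toward a higher number is expected in this assay and no step beyond the scatter. The estimated 1.2-fold higher number from compound 2 to compound 3 (0.07 log units; within the scatter) stays inside that scatter. Compound 3 is expected at 26000 nM with 11000 nM to 60000 nM as its estimated range.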

Compound 3, concentration for 50% growth inhibition: 47500 nM
Compound 3: the middle estimate sits 1.8-fold (0.26 log units) below what was measured; measured number inside the range.
By their numbers in this assay, from the lowest: compound 2; then compounds 3 and 1 (each within the scatter of the next).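

In this assay the exchange of chloro for fluoro on an aromatic carbon, ortho to a large group, gives a 2.2-fold higher number from compound 2 to compound 3 (0.33 log units; beyond the scatter) as the first step read at this position. This modest step shows that the position is sensitive to which halogen it carries, with the chloro of compound 2 giving the lower number of the pair. Nothing on hand accounts for the step.

Still open, going by these compounds, is how a methyl, a methoxy or an amine at this same place would compare with chloro and fluoro. Also open, on these data alone, is whether the same exchange at another place on that ring gives a step of like size.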